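The source may hold more compounds than are shown below. What is called first, only, known or untested is meant among the compounds shown, and "the series" means these compounds.

Compound 1 `COC(=O)CC/C(C)=C/Cc1c(OC)c(C)c2c(c1OCC#CCN1CCN(c3ccc(C#N)cc3)CC1)C(=O)OC2`: > 50000 nM (a limit)
Compound 2 `COC(=O)CC/C(C)=C/Cc1c(OC)c(C)c2c(c1OCC#CCN1CCN(c3ccc(O)cc3)CC1)C(=O)OC2`: > 50000 nM (a limit)
Compound 3 `COC(=O)CC/C(C)=C/Cc1c(OC)c(C)c2c(c1OCC#CCN1CCN(Cc3ccc(Cl)cc3)CC1)C(=O)OC2`: > 50000 nM (a limit)

In a functional assay on MDA-MB-231 cells (Homo sapiens) for inhibition, read by sulforhodamine B assay (a higher number here means a weaker inhibitor, a lower number a stronger inhibitor), compound 3 gives > 50000 nM, which is a limit of the assay and not a number. The other two compounds stand in the same place, and the whole series is described by the limit of > 50000 nM in this assay, at which 3 of the 3 values shown sit.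

The next compound is compound 4 `COC(=O)CC/C(C)=C/Cc1c(OC)c(C)c2c(c1OCC#CCN1CCN(C(=O)C3COc4ccccc4O3)CC1)C(=O)OC2`, which keeps the shared core and changes one group: (2,3-dihydro-1,4-benzodioxin-2-yl)carbonyl in place of 4-chlorobenzyl on an amine nitrogen in a ring. In words, (2,3-dihydro-1,4-benzodioxin-2-yl)carbonyl stands in place of 4-chlorobenzyl on an amine nitrogen in a ring.

Two measured steps changed the group on that same nitrogen: a step that the two limits leave unreadable from compound 1 to compound 3 and a step that the two limits leave unreadable from compound 2 to compound 3. A third changed a group on an aromatic carbon: a step that the two limits leave unreadable from compound 1 to compound 2. None of the three has a readable size, so they offer no measured size or direction to carry over. For the measured compounds named here, they show only that no compound so far has left the limit, and compound 4 is expected to stay there too. The step expected in this assay is a number no higher from compound 3 to compound 4 (the limit leaves the size open), with no direction expected beyond the scatter. For compound 4 the estimated value is 50000 nM, with an expected range of 20000 nM to 100000 nM.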

Compound 4, half-maximal inhibitory concentration: > 50000 nM
Compound 4: no number, only a limit (the forecaster's own chance of this, stated with the estimate: 80%); the middle value lies on the limit itself.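

In this assay compound 4 gives > 50000 nM, which is a limit of the assay and not a number. Its steps from compound 1, compound 2 and compound 3 therefore cannot be read, and the series stays in one place: the limit of > 50000 nM in this assay, at which 4 of the 4 values shown sit.

The compounds shown leave open whether any group on that ring nitrogen would give a measurable value.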